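A few compounds are considered here, and "the series" means these few. Any claim that something is new, unique, unknown or untested is made for them only; others in the source may bear on it.

Measured compounds:
- compound 1 `O=C1NC(=O)N(Cc2ccccc2)/C1=C/c1ccccc1`: 2.9%
- compound 2 `O=C1NC(=O)N(c2ccccc2)/C1=C/c1ccccc1`: 18%
- compound 3 `O=C1NC(=O)N(c2ccccc2)/C1=C\c1ccccc1`: 26%

In a functional assay on A549 cells (Homo sapiens) for antiproliferative activity, read by trypan blue exclusion, with a stated time of 72 h, tested at 20 uM (on this read-out lower numbers stand for less inhibition and higher numbers for more inhibition at the one concentration tested (going by the name of the read-out)), compound 2 stands second highest of the three numbers. Its nearest neighbour is compound 3, reached by a number 8 percentage points higher from compound 2 to compound 3 (within the scatter); the two compounds share all atoms and bonds, (the fact that compounds 2 and 3 differ only in the configuration as drawn), so this pair says little about substituents. Its furthest neighbour is compound 1, separated by a number 15.1 percentage points higher from compound 1 to compound 2 (beyond the scatter).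

Compound 4 `CN1C(=O)NC(=O)/C1=C\c1ccccc1` has not yet been measured. Set against compound 2, the change is methyl in place of phenyl on an amide-type nitrogen in a ring. Within the data shown here, the only measured step that bears on this position is the one from compound 1 to compound 2, where benzyl gave way to phenyl and the number rose by a number 15.1 percentage points higher from compound 1 to compound 2 (beyond the scatter), a modest move beyond the scatter. Replacing phenyl by methyl removes the aromatic ring altogether, a smaller substituent than either of those already seen, so the account expects no rise and more likely a fall, possibly back toward the level of compound 1, though whether the fall clears the scatter is uncertain.

Compound 4 is therefore estimated at 8%, within 0% to 22%, which corresponds to an expected step of a number 10 percentage points lower from compound 2 to compound 4 (within the scatter).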

Compound 4, a percentage reported as inhibition, at one concentration (the size of the read-out at that concentration, not a potency): 5.7%
Compound 4: middle estimate off by 2.3 percentage points, on the high side; the measured number falls inside the stated range.
By their numbers in this assay, from the lowest: compounds 1 and 4 (each within the scatter of the next); then compounds 2 and 3 (each within the scatter of the next).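

In this assay, methyl in place of phenyl on the amide-type nitrogen in a ring gives a number 12.3 percentage points lower from compound 2 to compound 4 (beyond the scatter) and so shows that this position can lose inhibition from compound 2 by a route other than the benzyl change. Hydrogen in place of phenyl on the saturated chain carbon gives a number 2.8 percentage points higher from compound 1 to compound 4 (within the scatter) and leaves compound 1 and compound 4 level, so among these three groups only phenyl bound directly to the nitrogen stands apart, while an aromatic ring alone does not set the level, as benzyl carries one and methyl none. Nothing on hand accounts for why phenyl stands apart from benzyl and methyl.

The compounds shown leave open whether a 4-methoxyphenyl or 4-chlorophenyl group, a longer chain such as n-butyl, or plain hydrogen on this nitrogen would keep, raise or lose the inhibition seen with phenyl. They also leave open whether the methyl compound would respond to the change of double-bond configuration drawn in the pair of compound 2 and compound 3, and how any of these readings at a single concentration would translate into potency.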